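The source may report more compounds than this note shows. Statements on the series, on what has been measured and on what is new or still open speak of the compounds shown alone.

Working notes on the series, read-out a functional assay on HL-60 cells (Homo sapiens) for antiproliferative activity, read by MTT assay, with a stated time of 72 h; on this read-out higher numbers stand for weaker inhibition and lower numbers for stronger inhibition.

Of the compounds shown here, three carry numbers so far. In this assay compound 1 `CCCOC(=O)N1CCN(/[N+]([O-])=N/Oc2cc(O/N=[N+](\[O-])N(C)C)c([N+](=O)[O-])cc2[N+](=O)[O-])CC1` gives 1600 nM and compound 2 `CN(C)/[N+]([O-])=N/Oc1cc(O/N=[N+](\[O-])N2CCN(c3ncccn3)CC2)c([N+](=O)[O-])cc1[N+](=O)[O-]` gives 1200 nM, the two differing only in that a pyrimidin-2-yl stands in place of propoxycarbonyl on an amine nitrogen in a ring; that one-place step, a 1.3-fold lower number from compound 1 to compound 2 (0.12 log units; within the scatter), stays within the scatter. Compound 3 `CN(C)/[N+]([O-])=N/Oc1cc(O/N=[N+](\[O-])N2CCCCC2)c([N+](=O)[O-])cc1[N+](=O)[O-]` gives 1700 nM in this assay. On the numbers shown compound 3 holds the highest of the three, yet its gap to compound 1 and its gap to compound 2 are both within the scatter, so no order among the three can be read.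

Compound 4 `CN(C)/[N+]([O-])=N/Oc1cc(O/N=[N+](\[O-])N2CCCC2)c([N+](=O)[O-])cc1[N+](=O)[O-]` is not yet measured. It differs from compound 3 by pyrrolidin-1-yl in place of piperidin-1-yl on a double-bonded nitrogen. For the measured compounds named here, no measured step touches this exact change. Going by the values given here, the only step available, from compound 1 to compound 2, alters a substituent on the ring amine attached to the same double-bonded nitrogen and stayed within the scatter, which is the sole guide here. For compound 4 the expected step is therefore no change at the digits printed from compound 3 to compound 4 (within the scatter), none beyond the scatter. Compound 4 is estimated at 1700 nM in this assay, with a range from 800 nM to 3600 nM.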

Compound 4, half-maximal inhibitory concentration: 2300 nM
Compound 4: middle estimate off by 1.4-fold (0.13 log units), on the low side; the measured number falls inside the stated range.
By their numbers in this assay, from the lowest: compounds 2, 1, 3 and 4 (each within the scatter of the next).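

In this assay, for the compounds shown here, pyrrolidin-1-yl in place of piperidin-1-yl on a double-bonded nitrogen gives a 1.4-fold higher number from compound 3 to compound 4 (0.13 log units; within the scatter), the first measured one-place change to the ring attached at this position, with a five-membered non-aromatic ring entering for a six-membered one. The earlier step, a 1.3-fold lower number from compound 1 to compound 2 (0.12 log units; within the scatter), altered only a substituent on a ring amine at the same place, so a change of the attached ring and a change of a group on such a ring have now both been read, and neither leaves the scatter. Nothing on hand offers an explanation for either step, and with both inside the scatter, no trend with ring size can be drawn from this single pair.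

On these data alone, what an open-chain diethylamino group, a morpholin-4-yl ring or a seven-membered azepan-1-yl ring would give at this position remains open. The dimethylamino group on the other double-bonded nitrogen is common to all four compounds, so replacing it with a longer chain or a ring amine also remains untested in the compounds shown.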